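Cyclopentylamino to Aminoethylamino on a Shared Core

A few compounds are considered here, and "the series" means these few. Any claim that something is new, unique, unknown or untested is made for them only; others in the source may bear on it.

Two compounds have numbers in an assay on isolated protein for binding affinity to adenosine receptor A3 (Homo sapiens), tested at 30 uM; a higher number here means a weaker inhibitor, a lower number a stronger inhibitor. Compound 1 `COC(=O)/C=C\Nc1cc(-c2ccncc2)nc2c1c(C)c(C)n2[C@H](C)c1ccccc1` gives 2640 nM, and compound 2 `Cc1c(C)n([C@H](C)c2ccccc2)c2nc(-c3ccccc3)nc(NC3CCCC3)c12` gives 8650 nM, the higher of the two; the gap between them lies beyond the usual scatter. Among the compounds with values here, the two differ in more than one place, so no single step is drawn between them. Compound 3 `Cc1c(C)n([C@H](C)c2ccccc2)c2nc(-c3ccccc3)nc(NCCN)c12` has not yet been measured in this assay. It differs from compound 2 in one place: 2-aminoethyl in place of cyclopentyl on a nitrogen on an aromatic ring. Within the data shown here, no measured pair shows this change, so nothing in the data fixes its size or direction. A move from a ring of carbon only to a short open chain carrying a donor and an acceptor could shift the value a little either way, and a modest weakening is taken as the expectation, a 1.7-fold higher number from compound 2 to compound 3 (0.24 log units; within the scatter). Compound 3 is therefore expected to give 15000 nM, within a range from 4000 nM to 60000 nM, with some chance that this assay reports only a limit.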

Compound 3, inhibition constant: 5580 nM
Beside the measured number, compound 3's estimate is 2.7-fold (0.43 log units) above it; low and high end bracket the measured number.
By their numbers in this assay, from the lowest: compound 1; then compounds 3 and 2 (each within the scatter of the next).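

In this assay, putting 2-aminoethyl in place of cyclopentyl on a nitrogen on an aromatic ring gives a 1.6-fold lower number from compound 2 to compound 3 (0.19 log units; within the scatter), so at this position a five-membered ring of carbon only and an open chain carrying a hydrogen-bond donor and acceptor cannot be told apart by their numbers. Within the data shown here, this is the first step that can be read at this position, since the earlier pair differed in more than one place. No available data explain this outcome.

The compounds shown leave open whether a longer chain ending in an amine, or a chain ending in a carboxylic acid, would also stay within the scatter of compound 2. They also leave open whether the same exchange would read alike on the core of compound 1.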